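The source may hold more compounds than are shown below. What is called first, only, known or untested is meant among the compounds shown, and "the series" means these compounds.

Among the compounds with values here, the two compounds measured so far in a functional assay on HepG2 cells (Homo sapiens) for antiproliferative activity, read by MTT assay, with a stated time of 48 h (on this read-out lower numbers stand for stronger inhibition and higher numbers for weaker inhibition), both stop at the assay's ceiling. Compound 1 `CC(=O)Nc1ccc(-n2nncc2CN2C(=O)C3(C(C#N)=C(N)Oc4c3c3nc5ccccc5nc3c3ccccc43)c3ccccc32)cc1` carries an acetamido-substituted phenyl on its triazole and an unsubstituted aromatic edge on the shared core; in this assay compound 1 gives only a limit, > 50000 nM. Compound 2 `Cc1ccccc1-n1nncc1CN1C(=O)C2(C(C#N)=C(N)Oc3c(N)cc4nc5ccccc5nc4c32)c2ccccc21` instead bears a 2-methylphenyl on the aromatic nitrogen and an amino group on the shared core; in this assay compound 2 likewise gives only a limit, > 50000 nM. Compound 2 therefore stands exactly where every value shown stands, because the limit of > 50000 nM in this assay, at which 2 of the 2 values shown sit, describes both measurements.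

Compound 3 `Cc1cc(C)cc(-n2nncc2CN2C(=O)C3(C(C#N)=C(N)Oc4c(N)cc5nc6ccccc6nc5c43)c3ccccc32)c1` differs from compound 2 in a single place: 3,5-dimethylphenyl in place of 2-methylphenyl on an aromatic nitrogen. Within the data shown here, no step between measured compounds is known, so no prior tells how this exchange should move the read-out. Given that compound 2 sits at the ceiling with > 50000 nM, the step expected from compound 2 to compound 3 in this assay is a step that the limit leaves unreadable from compound 2 to compound 3, none beyond the scatter. Compound 3 is accordingly expected to give about 60000 nM, in a range from 20000 nM to 200000 nM, most likely again only as a limit.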

Compound 3, half-maximal inhibitory concentration: > 50000 nM
Compound 3: a limit, no number (the forecaster's own chance of this, stated with the estimate: 80%); the middle value is on the limit's open side.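

No step can be read from compound 2 to compound 3 in this assay, because both give only a limit, and the same limit: the limit of > 50000 nM in this assay, at which 3 of the 3 values shown sit.

The compounds shown leave open whether 3,5-dimethylphenyl in place of 2-methylphenyl moves the read-out at all, and what number any of the three compounds would give.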